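Para substituent on the phenyl ring: bromo to methyl

The source may hold more compounds than are shown below. What is called first, only, known or untested is meant among the compounds shown, and "the series" means these compounds.

Measured compounds in a functional assay on aorta (strain Wistar) for inhibition, with Thoracic aorta (Rattus norvegicus) as the target; on this read-out higher numbers stand for weaker inhibition and lower numbers for stronger inhibition:
compound 1 `COc1nc(-c2cc3ccccc3o2)cc(-c2ccccc2)c1C#N`: 232000 nM
compound 2 `COc1nc(-c2cc3ccccc3o2)cc(-c2ccc(Br)cc2)c1C#N`: 298000 nM

For the measured compounds named here, compound 2 stands highest of the two numbers in this assay, but the single measured step, a 1.3-fold higher number from compound 1 to compound 2 (0.11 log units; within the scatter), lies within the scatter, so the two compounds are not distinguished. Compound 3 `COc1nc(-c2cc3ccccc3o2)cc(-c2ccc(C)cc2)c1C#N` differs from compound 2 by methyl in place of bromo on an aromatic carbon. Going by the values given here, the only step that bears on this place, exchanging hydrogen for bromo, moved the number by a 1.3-fold higher number from compound 1 to compound 2 (0.11 log units; within the scatter), within the scatter. On that basis the exchange of bromo for methyl is expected to give no step beyond the scatter, estimated as a 1.1-fold lower number from compound 2 to compound 3 (0.04 log units; within the scatter). Compound 3 is therefore estimated at 270000 nM, with a range from 130000 nM to 560000 nM in this assay.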

Compound 3, half-maximal inhibitory concentration: 266000 nM
Compound 3: middle estimate off by 1.0-fold (0.01 log units), on the high side; low and high end bracket the measured number.
By their numbers in this assay, from the lowest: compounds 1, 3 and 2 (each within the scatter of the next).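

In this assay a second substituent can now be read at this place on the phenyl ring: methyl for bromo gives a 1.1-fold lower number from compound 2 to compound 3 (0.05 log units; within the scatter), and methyl for hydrogen gives a 1.1-fold higher number from compound 1 to compound 3 (0.06 log units; within the scatter). Both steps lie within the scatter, so hydrogen, bromo and methyl are not distinguished at this place in the compounds shown. No evidence on hand bears on this result.

Still open, as far as these compounds go, is whether an amine, a carboxylic acid or a longer chain at this place would give a step beyond the scatter. Also open, from the compounds shown here alone, is whether changes elsewhere on the shared core would do so.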